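The source may report more compounds than this note shows. Statements on the series, on what has been measured and on what is new or still open speak of the compounds shown alone.

Compound 1 `Cc1cc(C)c2cccc(OCc3c(Cl)ccc(S(=O)(=O)NC4(C(=O)N5CCN(C(=O)[C@@H](N)CCCCN)CC5)CCCC4)c3Cl)c2n1` and compound 2 `Cc1cc(C)c2cccc(OCc3c(Cl)ccc(S(=O)(=O)NC4(C(=O)N5CCN(C(=O)[C@H](CCCCN(C)C)N(C)C)CC5)CCCC4)c3Cl)c2n1` share one core and differ only at a carbonyl carbon. In an assay on isolated protein for binding affinity to B1 bradykinin receptor (Homo sapiens) (on this read-out lower numbers stand for stronger inhibition and higher numbers for weaker inhibition), compound 1 gives only a limit of the assay, < 10000 nM. In this assay compound 2 likewise gives only a limit of the assay, < 10000 nM. The step that the two limits leave unreadable from compound 1 to compound 2 therefore cannot be read, because of the limit of < 10000 nM in this assay, at which 2 of the 2 values shown sit. Compound 3 `Cc1cc(C)c2cccc(OCc3c(Cl)ccc(S(=O)(=O)NC4(C(=O)N5CCN(C(=O)[C@@H](N)CCCC[N+](C)(C)C)CC5)CCCC4)c3Cl)c2n1` differs from compound 2 by a group of 10 heavy atoms (8 carbon, 2 nitrogen; no ring) in place of a group of 11 heavy atoms (9 carbon, 2 nitrogen; no ring), on a carbonyl carbon. Among the measured compounds shown here, no measured step gives a readable size for a change of this kind, so no direction beyond the scatter can be set. Compound 3 is therefore expected to give about 3000 nM, between 300 nM and 10000 nM, a step that the limit leaves unreadable from compound 2 to compound 3.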

Compound 3, inhibition constant: < 10000 nM
Compound 3: no number, only a limit (the forecaster's own chance of this, stated with the estimate: 70%); the middle value does not contradict the limit.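

In this assay, among the compounds shown here, compound 1, compound 2 and compound 3 all give only a limit of the assay, so no step among them can be read: the limit of < 10000 nM in this assay, at which 3 of the 3 values shown sit. Going by these compounds, how the groups on the carbonyl carbon compare in strength therefore stays open.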